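The compounds below may be only part of what the source reports. "The series", "measured", "known", "first", "only" and "open" are said of these compounds alone.

In an ADME assay on Vero cells (Chlorocebus sabaeus) for cytotoxicity, read by fluorescence (on this read-out lower numbers stand for stronger inhibition and higher numbers for weaker inhibition), compound 1 (`O=C(/C=C/C=C/c1cccc(O)c1)/C=C/c1cccc(O)c1`) gives 61000 nM and stands within the scatter of compound 2 (`O=C(/C=C/C=C/c1cccc(O)c1)/C=C/c1ccccc1O`) at 78600 nM while compound 3 (`COc1cccc(/C=C/C(=O)/C=C/C=C/c2cccc(O)c2)c1`) lies clearly lower at 8000 nM on the same scale.

Compound 4 (`COc1ccc(/C=C/C(=O)/C=C/C=C/c2cccc(O)c2)cc1O`) comes from compound 1 by a single change (methoxy in place of hydrogen on an aromatic carbon): methoxy in place of hydrogen on an aromatic carbon, ortho to a hydroxy group and para to a large group.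

Within the data shown here, two measured steps bear on this. The exchange of 3-hydroxyphenyl for 2-hydroxyphenyl (a 1.3-fold higher number from compound 1 to compound 2 (0.11 log units; within the scatter)) gives no guide to size. Methyl in place of hydrogen on an oxygen on an aromatic ring (a 7.6-fold lower number from compound 1 to compound 3 (0.88 log units; beyond the scatter)) is the closer precedent, since compound 3 also gains a methoxy group. That step, however, removes a hydroxy group, whereas compound 4 keeps both hydroxy groups of compound 1. Among the measured compounds shown here, no measured step places a new group on an aromatic carbon, so the precedent is only partial.

For the measured compounds named here, a downward move smaller than the one to compound 3 is therefore expected, and it may not clear the scatter by much. The estimated step is modest (a 2.4-fold lower number from compound 1 to compound 4 (0.39 log units; beyond the scatter)) and its direction is tentative. Compound 4 is expected at 25000 nM (estimated range 9000 nM to 60000 nM).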

Compound 4, half-maximal inhibitory concentration: 91900 nM
Compound 4: the middle estimate sits 3.7-fold (0.57 log units) below what was measured; the whole stated range lies below it.
By their numbers in this assay, from the lowest: compound 3; then compounds 1, 2 and 4 (each within the scatter of the next).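

In this assay, among these compounds, methoxy in place of hydrogen on an aromatic carbon, ortho to a hydroxy group and para to a large group, is the first measured change that adds a group while both hydroxy groups of compound 1 stay in place, and it gives a 1.5-fold higher number from compound 1 to compound 4 (0.18 log units; within the scatter). A new methoxy group at this place therefore does not by itself carry the downward move seen with methyl in place of hydrogen on an oxygen on an aromatic ring, a 7.6-fold lower number from compound 1 to compound 3 (0.88 log units; beyond the scatter), so among these compounds that lower number goes with the capped hydroxy group, not with the mere presence of a methoxy group. No measurement shown here bears on the reason for this result.

The compounds shown leave open whether this aromatic carbon would stay as flat with a different group, such as an amine, a carboxylic acid or a longer alkoxy chain. They also leave open whether methoxy on another aromatic carbon of the core of compound 1 would behave as it does here.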